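This account rests on a few compounds, and the source may have more. Where it says the series, first, only, none or still open, it means among the compounds named here.

Working notes on the series.

Among the measured compounds shown here, compound 1 `CCCc1ccc(NC(=O)C2CCN(C/C=C/c3ccccc3)CC2)cc1` in a functional assay on MGC-803 cells (Homo sapiens) for inhibition, read by MTT assay, with a stated time of 72 h (on this read-out lower numbers stand for stronger inhibition and higher numbers for weaker inhibition), gives 5210 nM, the highest of the two numbers known so far. Compound 2 `CCCCc1ccc(NC(=O)C2CCN(C/C=C/c3ccccc3)CC2)cc1` gives 2570 nM, and the step of a 2.0-fold lower number from compound 1 to compound 2 (0.31 log units; beyond the scatter) came from a methyl in place of hydrogen on a saturated chain carbon, three bonds along the chain from an aromatic carbon, so a longer chain on the aryl amide went with a stronger read-out.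

Compound 3 `O=C(Nc1cccc(F)c1)C1CCN(C/C=C/c2ccccc2)CC1` differs from compound 1 by 3-fluorophenyl in place of 4-propylphenyl on an amide-type nitrogen. For the measured compounds named here, no measured step replaces the alkyl chain by a halogen or shifts substitution from one ring position to another, so the only guidance is the direction of the chain-extension step. Shortening and swapping the substituent runs against that direction; a weaker read-out is therefore expected, though with wide uncertainty. In this assay compound 3 is estimated at 8000 nM, range 2500 nM to 25000 nM, a step of a 1.5-fold higher number from compound 1 to compound 3 (0.19 log units; within the scatter).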

Compound 3, half-maximal inhibitory concentration: 23300 nM
For compound 3 the middle estimate is 2.9-fold (0.46 log units) below the measured one; measured number inside the range.
By their numbers in this assay, from the lowest: compound 2; then compound 1; then compound 3.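

In this assay, 3-fluorophenyl in place of 4-propylphenyl on the amide-type nitrogen gives a 4.5-fold higher number from compound 1 to compound 3 (0.65 log units; beyond the scatter) and so moves the read-out in the weaker direction, whereas the earlier chain extension, a 2.0-fold lower number from compound 1 to compound 2 (0.31 log units; beyond the scatter), moved it in the stronger direction. This position therefore responds to a change of the whole aryl group as well as to chain length, but the loss of the propyl chain and the arrival of fluorine come together in this single step and cannot be told apart. Nothing available accounts for the size or direction of this step.

Going by these compounds, whether an unsubstituted phenyl would sit closer to compound 1 or to compound 3 remains open, as does the effect of fluorine on its own. It is also unknown whether a pentyl chain would extend the direction seen with compound 2.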